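A few compounds are considered here, and "the series" means these few. Any claim that something is new, unique, unknown or untested is made for them only; others in the source may bear on it.

For the measured compounds named here, in an assay on isolated protein for inhibition of histamine H2 receptor (Cavia porcellus) (on this read-out higher numbers stand for weaker binding and lower numbers for tighter binding), compound 2 `O=C(NCCCOc1cccc(CN2CCCCC2)c1)Nc1ccc(C(F)(F)F)cc1` gives 1700 nM, one of only two numbers measured so far, and the other, compound 1 `COc1ccc(NC(=O)NCCCOc2cccc(CN3CCCCC3)c2)c(OC)c1`, gives 2240 nM. These two values lie close together: a 1.3-fold lower number from compound 1 to compound 2 (0.12 log units; within the scatter), a change that falls inside the usual scatter. Compound 3 `CCC(C)NC(=O)NCCCOc1cccc(CN2CCCCC2)c1` has not yet been measured. It differs from compound 2 in a single place: sec-butyl in place of 4-(trifluoromethyl)phenyl on an amide-type nitrogen. Going by the values given here, the one measured step exchanged one aromatic group for another on the same nitrogen and left the number essentially unchanged, so the available evidence says only that this position tolerates a swap between two aromatic groups. Among the compounds with values here, the step to compound 3 is of a different kind, an aromatic ring giving way to a short chain, and no measured pair covers such a change. With so little to go on, the step expected in this assay is a 1.8-fold higher number from compound 2 to compound 3 (0.25 log units; within the scatter), carrying a wide band of uncertainty in either direction. Compound 3 is therefore estimated at 3000 nM, with a range from 800 nM to 12000 nM.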

Compound 3, dissociation constant: 95.5 nM
Beside the measured number, compound 3's estimate is 31-fold (1.50 log units) above it; the measured number lies below the stated range.
By their numbers in this assay, from the lowest: compound 3; then compounds 2 and 1 (each within the scatter of the next).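

In this assay, what sits on this amide-type nitrogen turns out to matter a great deal: putting sec-butyl in place of 4-(trifluoromethyl)phenyl gives an 18-fold lower number from compound 2 to compound 3 (1.25 log units; beyond the scatter) and putting it in place of 2,4-dimethoxyphenyl gives a 23-fold lower number from compound 1 to compound 3 (1.37 log units; beyond the scatter) on the same core. For the compounds shown here, the earlier pair held only two aromatic groups, whose numbers lay within the scatter of each other, so it could not show that a group with no ring and fewer heavy atoms goes with much tighter binding here. Nothing available explains why the number falls so far with this exchange.

With sec-butyl as the only open chain among the compounds shown, it remains open whether a shorter chain such as ethyl, a longer chain such as n-hexyl, or a saturated ring such as cyclohexyl would bind as tightly. As far as these compounds go, it also remains open how an amine or a carboxylic acid carried on such a chain would fare at this nitrogen.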